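The compounds below may be only part of what the source reports. "The series", "measured", "known", "first", "only" and "open" are said of these compounds alone.

Compound 1 `Nc1ccc2cccc(OCC3CC4CCC3C4)c2n1` — 1730 nM
Compound 2 `CC(CC(C)(C)C)Oc1cccc2ccc(N3CCCC3)nc12` — > 10000 nM

In a functional assay on IMR-32 cells with melanin-concentrating hormone receptor 1 (Homo sapiens) as the target, read by fluorescence (on this read-out higher numbers stand for weaker inhibition and lower numbers for stronger inhibition), compound 1 gives 1730 nM. For compound 2 the assay reports only a limit, > 10000 nM, so compound 2 sits at the limit of > 10000 nM in this assay, at which 1 of the 2 values shown sits. Compound 3 `CC(CC(C)(C)C)Oc1cccc2cccnc12` differs from compound 2 by a single change: hydrogen in place of pyrrolidin-1-yl on an aromatic carbon. Among the compounds with values here, no measured pair shows this change, so its size is unknown; starting from a limit, no step beyond the usual scatter can be expected in either direction, and a limit is again likely. The estimate for compound 3 is 15000 nM, between 4000 nM and 60000 nM, expected as a step that the limit leaves unreadable from compound 2 to compound 3.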

Compound 3, half-maximal inhibitory concentration: > 10000 nM
Compound 3: a limit, no number (the forecaster's own chance of this, stated with the estimate: 75%); the middle value is on the limit's open side.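

Compound 2 and compound 3 are both reported only as limits, so no step can be read between them. On these data alone, how much hydrogen in place of pyrrolidin-1-yl changes inhibition, if at all, remains open.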